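The source may report more compounds than this note shows. Statements on the series, on what has been measured and on what is new or still open speak of the compounds shown alone.

- compound 1 `CC1(C)CCc2cc(C(=O)/C=C/c3ccc(OCc4cn(-c5ccc(Br)cc5)nn4)cc3)c(O)cc2O1`: 69400 nM
- compound 2 `Cc1c(-n2cc(COc3ccc(/C=C/C(=O)c4cc5c(cc4O)OC(C)(C)CC5)cc3)nn2)cccc1[N+](=O)[O-]`: "not active" (no number reported)
- compound 3 `CC1(C)CCc2c(ccc(C(=O)/C=C/c3ccc(OCc4cn(-c5ccc(Br)cc5)nn4)cc3)c2O)O1`: 117000 nM

All three results come from a functional assay on IMR-32 cells (Homo sapiens) for antiproliferative activity, read by MTT assay; a lower number here means a stronger inhibitor, a higher number a weaker inhibitor. Among the compounds with values here, only two compounds have a number, and compound 3 lies within the scatter of compound 1, so the data do not rank one above the other. Compound 2 has no number to compare.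

Compound 4 `CCCCCn1cc(COc2ccc(/C=C/C(=O)c3ccc4c(c3O)CCC(C)(C)O4)cc2)nn1` has not been measured yet. It keeps the core of compound 3 and changes one group, with pentyl in place of 4-bromophenyl on an aromatic nitrogen. A ring on that nitrogen thus gives way to an open chain.

Within the data shown here, no measured pair shows this exchange, so the data offer only indirect guidance. Compound 1 and compound 3 both carry 4-bromophenyl, while compound 2 carries a different group at that nitrogen and gave no number. A result without a number for compound 4 therefore remains possible.

If a number is reported in this assay, no step beyond the scatter is expected, and the direction is uncertain. The estimate corresponds to an expected 1.5-fold lower number from compound 3 to compound 4 (0.17 log units; within the scatter). For compound 4 the estimated value is 80000 nM, with an expected range from 25000 nM to 200000 nM.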

Compound 4, half-maximal inhibitory concentration: "not active" (no number reported)
Nothing numeric was reported for compound 4; no gap can be computed for the estimate.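

In this assay compound 4 is reported as not active with no number, whereas compound 3 gives 117000 nM as its result, so no step can be read between these two compounds. Nothing measured here offers an explanation for this result. The compounds shown leave open how pentyl and 4-bromophenyl on that aromatic nitrogen compare in this assay in numbers.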